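The source may hold more compounds than are shown below. What is called first, only, known or untested is meant among the compounds shown, and "the series" means these compounds.

Working notes on the series.

Of the compounds shown here, three have been measured in an assay for inhibition of Dihydrofolate reductase (Homo sapiens); on this read-out lower numbers stand for lower potency and higher numbers for higher potency (the scale is a negative logarithm). Compound 1 `O=c1[nH]c(=O)c2cc(Sc3ccc4ccccc4c3)ccc2[nH]1` gives 5.07 in this assay. Compound 2 `Cc1cccc2nc(N)nc(N)c12` gives 6.09. Compound 3 `Nc1nc(N)c2c(Cl)c(NC(=O)CCc3ccc(Cl)cc3)ccc2n1` gives 7.44, the highest of the three numbers; the nearest is compound 2, whose number is lower by a margin beyond the scatter, and the furthest is compound 1, whose number is lower by a wider margin, also beyond the scatter. Within the data shown here, no two of the measured compounds differ in only one place, so no single step has been characterised.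

The next compound, compound 4 `Cc1c(NC(=O)CCc2ccc(Cl)cc2)ccc2nc(N)nc(N)c12`, is not yet measured. It differs from compound 3 in one place: methyl in place of chloro on an aromatic carbon. The chloro leaves and the methyl enters on the same aromatic carbon of the fused carbon ring.

With no measured step of this kind in the set, the expectation rests on compound 3 at 7.44 and on compound 2, which carries the same methyl on its core and gives 6.09. The step in this assay is expected to be small, a number 0.24 log units lower from compound 3 to compound 4 (within the scatter), in the downward direction, and it may well fall within the scatter. Compound 4 is therefore estimated at 7.2, with a range from 6.6 to 7.8.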

Compound 4, logarithm of the reciprocal of the active concentration, log(1/C): 7.48
For compound 4 the middle estimate is 0.28 log units below the measured one; the range from low to high includes it.
By their numbers in this assay, from the lowest: compound 1; then compound 2; then compounds 3 and 4 (each within the scatter of the next).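

In this assay, among these compounds, the exchange of chloro for methyl on this aromatic carbon, ortho to a large group, gives a number 0.04 log units higher from compound 3 to compound 4 (within the scatter) and is the first single-place step that can be read. On this read-out, the position therefore accepts either of these two groups, each of one heavy atom with no hydrogen-bond donors or acceptors, without a difference that stands out from the scatter, at least with the amide side chain shared by these two compounds in place. Nothing measured here bears on why the two groups read alike.

As far as these compounds go, whether an amine, a methoxy group, a carboxylic acid or a longer chain such as propyl on this aromatic carbon would also read alike remains open, since a single step says nothing about how far this tolerance extends. Also open, from the compounds shown here alone, is whether chloro and methyl read alike when the amide side chain is absent, a question that compound 2 alone cannot settle.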